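The source may report more compounds than this note shows. Statements on the series, on what has been measured and on what is new or still open speak of the compounds shown alone.

Measured compounds in an assay on HeLa cells for displacement of a labelled ligand from adenosine receptor A3 (Homo sapiens), read by fluorescence polarization, with a stated time of 30 min; on this read-out lower numbers stand for stronger inhibition and higher numbers for weaker inhibition:
- compound 1, `COc1ccc(-c2cc(NC(=O)COCC(=O)NCC(=O)NC3CCCCC3)nc(-c3ccc(OC)cc3)n2)cc1` — compound 1 gives 14000 nM
- compound 2, `COc1ccc(-c2cc(NC(=O)CCC(=O)N3CCN(CC(=O)NC4CCCCC4)CC3)nc(-c3ccc(OC)cc3)n2)cc1` — compound 2 gives 10500 nM

Both carry the shared core and differ in the linker that joins the core to the terminal cyclohexylcarbamoyl end. Compound 2 has the lowest of the two numbers in this assay, but its gap to compound 1 is within the scatter, so the two cannot be ranked against each other; they read as one level of weak inhibition.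

The next compound to be measured is compound 3, `COc1ccc(-c2cc(NC(=O)CCC(=O)N3CCN(CC(=O)NCc4ccccc4)CC3)nc(-c3ccc(OC)cc3)n2)cc1`. Relative to compound 2 the change is benzyl in place of cyclohexyl on an amide-type nitrogen. Among the measured compounds shown here, no measured pair in this set shows this exchange, so there is no step to lean on. Within the two numbers to hand nothing suggests that the terminal group drives the read-out, and the expectation for compound 3 is therefore no step beyond the scatter, with a wide range in this assay.

For compound 3 the estimated step from compound 2 is a 1.2-fold lower number from compound 2 to compound 3 (0.07 log units; within the scatter). Compound 3 is expected to give about 9000 nM in this assay, with the range 3500 nM to 25000 nM.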

Compound 3, inhibition constant: 3400 nM
For compound 3 the middle estimate is 2.6-fold (0.42 log units) above the measured one, outside the stated range (below it).
By their numbers in this assay, from the lowest: compound 3; then compounds 2 and 1 (each within the scatter of the next).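

In this assay, among the compounds shown here, the terminal group on the amide-type nitrogen proves able to move the read-out: benzyl in place of cyclohexyl gives a 3.1-fold lower number from compound 2 to compound 3 (0.49 log units; beyond the scatter) and, with the linker and the shared core unchanged, this modest step is the first to lie beyond the scatter. Compound 1 and compound 2 both end in cyclohexyl, so neither could show anything about this position, whereas the pair of compound 2 and compound 3 isolates it. No measurement at hand accounts for the step.

The exchange swaps a non-aromatic ring for an aromatic one and also adds one carbon, so a cyclohexylmethyl or a phenyl group on the same nitrogen would be needed to tell these two differences apart, and a phenethyl group or a methoxy substituent on the benzyl ring would show whether the trend extends further. On these data alone, it also remains open whether benzyl gives a similar step on the linker of compound 1, since the present step rests on a single pair.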